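This account rests on a few compounds, and the source may have more. Where it says the series, first, only, none or still open, it means among the compounds named here.

The measured compounds:

compound 1, `ClCc1ccc(Cn2cnc3c(Cl)ncnc32)cc1`, 1000 nM
compound 2, `ClCc1cccc(Cn2cnc3c(Cl)nc(Cl)nc32)c1`, 1690 nM

In a functional assay on LOX IMVI cells (Homo sapiens) for cytotoxicity, read by sulforhodamine B assay, with a stated time of 48 h (a lower number here means a stronger inhibitor of growth, a higher number a weaker inhibitor of growth), compound 1 gives 1000 nM, the lowest of the two numbers. Within the data shown here, the only other measured compound, compound 2, gives 1690 nM in this assay, and the gap to compound 1 lies within the scatter, so the two values cannot be told apart. Among the measured compounds shown here, no pair of measured compounds differing in one place is available, and nothing in these data speaks to the change that leads to compound 3, `Nc1nc(Cl)c2ncn(Cc3ccc(CCl)cc3)c2n1`. Compound 3 differs from compound 1 by amino in place of hydrogen on an aromatic carbon. For the measured compounds named here, with no comparable step to draw on, the expected size of the step from compound 1 to compound 3 in this assay is none beyond the scatter, in either direction. The estimate for compound 3 is therefore 1500 nM, within 500 nM to 4500 nM, meaning an expected step of a 1.5-fold higher number from compound 1 to compound 3 (0.18 log units; within the scatter).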

Compound 3, concentration for 50% growth inhibition: 5370 nM
Compound 3: middle estimate off by 3.6-fold (0.55 log units), on the low side, outside the stated range (above it).
By their numbers in this assay, from the lowest: compounds 1 and 2 (each within the scatter of the next); then compound 3.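

In this assay, among these compounds, amino in place of hydrogen on an aromatic carbon, between two ring nitrogen atoms, gives a 5.4-fold higher number from compound 1 to compound 3 (0.73 log units; beyond the scatter), a modest step and the first readable single change in this set. This position is therefore not indifferent to substitution: compound 3, with the amino group, is the weaker inhibitor of growth, and the hydrogen of compound 1 goes with the lower number. Nothing available explains this step.

Going by these compounds, whether the loss belongs to amino in particular or would follow any group at this carbon remains open, and a methylamino, dimethylamino, hydroxyl or methyl group there would help to separate those readings. A single step on one core also leaves open whether amino would have a similar effect on a different core.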